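Expected value for compound 4

The source may report more compounds than this note shows. Statements on the series, on what has been measured and on what is new or still open speak of the compounds shown alone.

Values so far in a functional assay on MCF7 cells (Homo sapiens) for antiproliferative activity, with a stated time of 5 days (on this read-out higher numbers stand for weaker inhibition and lower numbers for stronger inhibition), are:
- compound 1 `CCCCc1ccc2[nH]c(-c3ccc(OC)cc3)c(/C=N/NC(=O)c3ccccc3)c2c1` gives 130 nM
- compound 2 `CCCCc1ccc2[nH]c(-c3ccc(OC)cc3)c(/C=N/NC(=O)c3ccc(Cl)cc3)c2c1` gives 220 nM
- compound 3 `CCCCc1ccc2[nH]c(-c3ccc(OC)cc3)c(/C=N/NC(=O)c3cccc(OC)c3)c2c1` gives "not determined" (no result reported)

Compound 3 has no number in this assay and so offers no measured starting point. Its step to compound 4 `CCCCc1ccc2[nH]c(-c3ccc(OC)cc3)c(/C=N/NC(=O)c3ccc([N+](=O)[O-])cc3)c2c1` is 4-nitrophenyl in place of 3-methoxyphenyl on a carbonyl carbon and amounts to 4-nitrophenyl in place of 3-methoxyphenyl on a carbonyl carbon. Going by the values given here, the only measured step available is a 1.7-fold higher number from compound 1 to compound 2 (0.23 log units; within the scatter) and it places chloro in place of hydrogen on an aromatic carbon. That step is a weak guide to this different change. No departure beyond the scatter from the values of compound 1 and compound 2 is expected. Compound 4 is estimated at 200 nM (expected range 70 nM to 600 nM).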

Compound 4, half-maximal inhibitory concentration: 312 nM
The estimate for compound 4 lay 1.6-fold (0.19 log units) below the measured number, within the range that was stated.
By their numbers in this assay, from the lowest: compounds 1, 2 and 4 (each within the scatter of the next, the first and the last beyond it).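

In (this assay), the 4-nitrophenyl group on the carbonyl carbon opens the first gap beyond the scatter in this series (a 2.4-fold higher number from compound 1 to compound 4 (0.38 log units; beyond the scatter)), though only a modest one. Nitro and chloro are not told apart here (a 1.4-fold higher number from compound 2 to compound 4 (0.15 log units; within the scatter)), as that step stays within the scatter. The step from compound 3 cannot be read, and nothing at hand explains the result. Going by these compounds, whether an amine or a carboxylic acid in the same place would stay with these values remains open.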